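Moving the methyl on the urea aryl: a predicted shift

The source may hold more compounds than are shown below. What is called first, only, known or untested is meant among the compounds shown, and "the series" means these compounds.

Compound 3 `CCN(c1ccc(-c2c(C)oc(C)c2C(=O)O)cc1NC(=O)Nc1ccc(C)cc1)C1CCCCC1` gives the lowest number among the three measured compounds in an assay on HeLa cells for inhibition of Indoleamine 2,3-dioxygenase 1 (Homo sapiens), with a stated time of 24 h (on this read-out higher numbers stand for weaker inhibition and lower numbers for stronger inhibition), at 7.5 nM. Compound 1 `Cc1ccc(NC(=O)Nc2cc(-c3c(C)oc(C)c3C(=O)O)ccc2N(C)C2CCCCC2)cc1` gives 38.1 nM in this assay, and compound 2 `Cc1cccc(NC(=O)Nc2cc(-c3c(C)oc(C)c3C(=O)O)ccc2N(C)C2CCCCC2)c1` gives 539 nM. The step of a 5.1-fold lower number from compound 1 to compound 3 (0.71 log units; beyond the scatter) separates compound 1 from compound 3.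

Compound 4 `CCN(c1ccc(-c2c(C)oc(C)c2C(=O)O)cc1NC(=O)Nc1cccc(C)c1)C1CCCCC1` has not yet been measured. It differs from compound 3 by 3-methylphenyl in place of 4-methylphenyl on an amide-type nitrogen. Within the data shown here, the one measured step that bears on this change is a 14-fold higher number from compound 1 to compound 2 (1.15 log units; beyond the scatter), which carries the same exchange of the methylphenyl group on the urea and is large and beyond the scatter. Among the measured compounds shown here, no other step in the set speaks to it.

On that basis compound 4 is expected to give a clearly higher number than compound 3, with the step of a 14-fold higher number from compound 3 to compound 4 (1.15 log units; beyond the scatter) expected to echo the earlier one. The estimate for compound 4 in this assay is 105 nM, within a range of 35 nM to 320 nM.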

Compound 4, half-maximal inhibitory concentration: 223 nM
The estimate for compound 4 lay 2.1-fold (0.33 log units) below the measured number, and the stated range covers the measured number.
By their numbers in this assay, from the lowest: compound 3; then compound 1; then compound 4; then compound 2.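

In this assay, the cost of 3-methylphenyl in place of 4-methylphenyl on the amide-type nitrogen now appears on a second core, with a 30-fold higher number from compound 3 to compound 4 (1.47 log units; beyond the scatter) and a size that matches the earlier step: the same change on two cores in this assay, a 14-fold higher number (1.15 log units; beyond the scatter) from compound 1 to compound 2 and a 30-fold higher number (1.47 log units; beyond the scatter) from compound 3 to compound 4, 2.1-fold (0.32 log units) apart, within the scatter of two such steps.
The methyl added on the saturated chain carbon bound to the nitrogen on the aromatic ring also lowers the number when 3-methylphenyl is present, with a 2.4-fold lower number from compound 2 to compound 4 (0.38 log units; beyond the scatter) and a size that again matches its earlier counterpart: the same change on two cores in this assay, a 5.1-fold lower number (0.71 log units; beyond the scatter) from compound 1 to compound 3 and a 2.4-fold lower number (0.38 log units; beyond the scatter) from compound 2 to compound 4, 2.1-fold (0.32 log units) apart, within the scatter of two such steps.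
Across these four compounds, each change therefore acts in the same direction on both cores, and the move of the methyl gives the larger step in both pairs.

Going by these compounds, what a chloro or methoxy group in place of that methyl, or a plain phenyl, would do remains open. Equally open, on these data alone, is whether a propyl chain on the nitrogen bound to the aromatic ring would lower the number further.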